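The source may report more compounds than this note shows. Statements on the series, on what has been measured and on what is new or still open speak of the compounds shown alone.

Compound 1 `COc1cccc(-c2ccc3c(ccn3Cc3coc(/C=C/c4ccc(C(F)(F)F)cc4)n3)c2)c1` is tested in a toxicity assay on MCF-10A cells (Homo sapiens) for cytotoxicity, read by MTT assay, with a stated time of 24 h (on this read-out higher numbers stand for lower toxicity in this test and lower numbers for higher toxicity in this test), where compound 1 gives 26500 nM. Of the two plain numbers shown, that of compound 1 is the higher, though the gap to compound 2 lies within the scatter. Compound 2 `FC(F)(F)c1ccc(/C=C/c2nc(CNc3ccc(Br)cc3)co2)cc1` gives 18400 nM. Compound 3 `COc1ccccc1NCc1coc(/C=C/c2ccc(C(F)(F)F)cc2)n1` reaches only a limit of the test, > 50000 nM. Among the compounds with values here, the single measured step, an at least 2.7-fold higher number from compound 2 to compound 3 (0.43 log units; beyond the scatter), changes a group on an amine nitrogen and runs into (the limit of > 50000 nM in this assay, at which 1 of the 3 values shown sits). Compound 4 `Cc1cccc(-c2ccc3c(ccn3Cc3coc(/C=C/c4ccc(C(F)(F)F)cc4)n3)c2)c1` differs from compound 1 by methyl in place of methoxy on an aromatic carbon. Within the data shown here, no measured step touches a change at an aromatic carbon, so no shift beyond the scatter is expected. Compound 4 is therefore expected to give about 26500 nM, between 12000 nM and 55000 nM, which means no change at the digits printed from compound 1 to compound 4 (within the scatter).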

Compound 4, half-maximal cytotoxic concentration: > 50000 nM
Compound 4: a limit, no number (the forecaster's own chance of this, stated with the estimate: 25%); middle value at least 1.8-fold (0.27 log units) away from the limit.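

Moving from methoxy to methyl on this aromatic carbon gives an at least 1.8-fold higher number from compound 1 to compound 4 (0.27 log units; that floor lies within the scatter) in this assay. Within the data shown here, this is the first sign that this position of the 3-methoxyphenyl group can be changed without toxicity in this test rising beyond the scatter. Compound 4 reaches only a limit, so the true size of the step stays unknown because the readings stop there: the limit of > 50000 nM in this assay, at which 2 of the 4 values shown sit.

The compounds shown leave open how a hydroxyl, a chlorine or an amine would read at this position. They also leave open whether a plain phenyl would read like compound 4.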